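Neopentyloxy in place of trifluoromethylphenoxy: mouse microsomal clearance

The source may hold more compounds than are shown below. What is called first, only, known or untested is meant among the compounds shown, and "the series" means these compounds.

Compound 1 `CCS(=O)(=O)Nc1ccc(Oc2ccc(C#N)cc2)c(-c2cn(C)c(=O)c3[nH]ccc23)c1` reaches only a limit, < 109 mL/min/kg, in an ADME assay on microsomes from liver (Mus musculus) for metabolic stability; a higher number here means faster removal of the compound, a lower number slower removal. Among the compounds with values here, compound 2 `CCS(=O)(=O)Nc1ccc(Oc2ccc(C(F)(F)F)cc2)c(-c2cn(C)c(=O)c3[nH]ccc23)c1` gives 2830 mL/min/kg, the sole numeric value shown, and the step of an at least 25-fold higher number from compound 1 to compound 2 (1.41 log units; beyond the scatter) is the only measured one. Compound 3 `CCS(=O)(=O)Nc1ccc(OCC(C)(C)C)c(-c2cn(C)c(=O)c3[nH]ccc23)c1` differs from compound 2 by neopentyl in place of 4-(trifluoromethyl)phenyl on an oxygen on an aromatic ring. Within the data shown here, no measured step covers an alkyl group in place of an aryl group on that oxygen; the one known step shows that what sits there moves this assay strongly, so a sizeable step is expected. Compound 3 is expected at 800 mL/min/kg (range 150 mL/min/kg to 3500 mL/min/kg), a step of a 3.5-fold lower number from compound 2 to compound 3 (0.55 log units; beyond the scatter).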

Compound 3, clearance: 1030 mL/min/kg
Estimate against measurement, compound 3: 1.3-fold (0.11 log units) below; the measured number falls inside the stated range.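

Putting neopentyl on this oxygen removes the whole ring and gives a 2.7-fold lower number from compound 2 to compound 3 (0.44 log units; beyond the scatter) in this assay, so an alkyl group can also lower the number that 4-(trifluoromethyl)phenyl gives here. Even so, neopentyl does not match the 4-cyanophenyl group, with an at least 9.4-fold higher number from compound 1 to compound 3 (0.97 log units; beyond the scatter). The figure for compound 1 is a limit, so that step has only a lower bound: the limit of < 109 mL/min/kg in this assay, at which 1 of the 3 values shown sits.

On these data alone, it remains open how a shorter chain such as ethyl, or an amine on the chain, would read at this oxygen. As far as these compounds go, it is also open whether a nitrile on an alkyl group would bring the number down as it does on the ring.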